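The source may hold more compounds than are shown below. What is called first, only, known or untested is meant among the compounds shown, and "the series" means these compounds.

Of the compounds shown here, three with a shared core have been tested in an ADME assay on HeLa cells (Homo sapiens) for cytotoxicity, read by ATP content, with a stated time of 3 days; a lower number here means that less compound is tolerated, a higher number that more compound is tolerated. Compound 1 `COc1ccc(-n2c(=O)n(Cc3cc4cc(Cl)ccc4n3CCCC#N)c3cnccc32)c(F)c1` gives > 50000 nM, which is a limit of the assay rather than a number. Compound 2 `CS(=O)(=O)CCCn1c(Cn2c(=O)n(C3CC3)c3ccncc32)cc2ccccc21` gives > 100000 nM, again a limit. Compound 3 `O=C(O)CCCn1c(Cn2c(=O)n(C3CC3)c3ccncc32)cc2cc(Cl)ccc21` gives > 50000 nM, also a limit. Compound 3 therefore stands at the limit of > 50000 nM in this assay, at which 2 of the 3 values shown sit, while compound 2 sits at the limit of > 100000 nM in this assay, at which 1 of the 3 values shown sits. None of the three shows a measurable value. Compound 4 `NC(=O)CCCn1c(Cn2c(=O)n(C3CC3)c3ccncc32)cc2cc(Cl)ccc21` has not yet been measured; it differs from compound 3 by amino in place of hydroxy on a carbonyl carbon. Every measured compound stays at a limit, so the step that the limit leaves unreadable from compound 3 to compound 4 in this assay is expected to lie within the scatter, if it registers at all. Compound 4 is estimated at 60000 nM, within a range from 20000 nM to 200000 nM.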

Compound 4, half-maximal cytotoxic concentration: > 50000 nM
Compound 4: a limit, no number; the forecaster's own chance of this, stated with the estimate: 85%; the middle value lies beyond the limit too.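

Among these compounds, compound 3 and compound 4 both give a limit rather than a number in this assay, so no step between them can be read. The compounds shown leave open what half-maximal cytotoxic concentration any of them actually has.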